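A few compounds are considered here, and "the series" means these few. Any claim that something is new, unique, unknown or untested is made for them only; others in the source may bear on it.

Measured in a functional assay on MCF7 cells (Homo sapiens) for inhibition, read by sulforhodamine B assay; a higher number here means a weaker inhibitor of growth, a lower number a stronger inhibitor of growth:
- compound 1 `Oc1cccc2[nH]c(-c3ccc(-c4ccc(-c5ccc(C(F)(F)F)cc5)cc4)cc3)nc12`: 2310 nM
- compound 2 `Oc1cccc2[nH]c(-c3ccc(-c4ccc(-c5ccc(OC(F)(F)F)cc5)cc4)cc3)nc12`: 2210 nM
- compound 3 `COc1ccc(-c2ccc(-c3ccc(-c4nc5c(O)cccc5[nH]4)cc3)cc2)cc1`: 3110 nM

Compound 3, at 3110 nM, is not separated from the other two compounds. The steps are a 1.3-fold higher number from compound 1 to compound 3 (0.13 log units; within the scatter) and a 1.4-fold higher number from compound 2 to compound 3 (0.15 log units; within the scatter).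

The next compound is compound 4 `COc1ccc(-c2ccc(-c3ccc(-c4nc5c(O)cccc5[nH]4)cc3)cc2)cc1OC`, which has methoxy in place of hydrogen on an aromatic carbon, taking 4-methoxyphenyl to 3,4-dimethoxyphenyl: methoxy in place of hydrogen on an aromatic carbon.

The closest evidence comes from group exchanges on the same ring: a 1.0-fold lower number from compound 1 to compound 2 (0.02 log units; within the scatter), along with the two steps above. All three stay within the scatter in this assay. None of them adds a second group to the ring, so they bear on this change only indirectly. With that caveat, no step beyond the scatter is expected, and no direction can be assigned with confidence.

The expected step is a 1.0-fold lower number from compound 3 to compound 4 (0.02 log units; within the scatter). For compound 4 the estimated value is 3000 nM, with an expected range of 1500 nM to 6000 nM.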

Compound 4, concentration for 50% growth inhibition: 190 nM
The estimate for compound 4 lay 16-fold (1.20 log units) above the measured number; the measured number lies below the stated range.
By their numbers in this assay, from the lowest: compound 4; then compounds 2, 1 and 3 (each within the scatter of the next).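

Within the data shown here, in (this assay), the change from 4-methoxyphenyl to 3,4-dimethoxyphenyl gives the first step beyond the scatter (a 16-fold lower number from compound 3 to compound 4 (1.21 log units; beyond the scatter)), whereas the exchanges among trifluoromethyl, trifluoromethoxy and methoxy all stayed within it. The result also separates the new compound from both other members of the series (a 12-fold lower number from compound 2 to compound 4 (1.07 log units; beyond the scatter); a 12-fold lower number from compound 1 to compound 4 (1.08 log units; beyond the scatter)). Growth inhibition therefore responds strongly to a methoxy on this aromatic carbon, ortho to a methoxy group and meta to a large group, a sensitivity that the single-group exchanges on this ring did not reveal.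

From the compounds shown here alone, whether a 3-methoxyphenyl ring alone would give the same result remains open, as does the effect of an amine, a carboxylic acid or a longer alkoxy chain on this carbon. No supporting measurement is available to explain the size of this step.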